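Swapping chloro for methoxy on the pyridine ring

The source may report more compounds than this note shows. Statements on the series, on what has been measured and on what is new or still open speak of the compounds shown alone.

Measured so far in an assay on isolated protein for inhibition of Rho-associated protein kinase 1 (Homo sapiens), read by radiometric assay and 33P incorporation, with a stated time of 40 min, in the presence of a further agent that is not named here; on this read-out lower numbers stand for stronger inhibition and higher numbers for weaker inhibition:
compound 1 `COc1cccc(Cn2cnc3sc(-c4ccnc(F)c4)cc3c2=O)c1`, 1050 nM
compound 2 `COc1cccc(Cn2cnc3sc(-c4ccnc(Cl)c4)cc3c2=O)c1`, only a limit, > 10000 nM

Compound 2 shows no number in this assay; its value is a limit, (the limit of > 10000 nM in this assay, at which 1 of the 2 values shown sits). Going by the values given here, compound 1 sits well inside the measured range, and the one measured step, an at least 9.5-fold higher number from compound 1 to compound 2 (0.97 log units; beyond the scatter), went from a number to that limit.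

Compound 3 `COc1cccc(Cn2cnc3sc(-c4ccnc(OC)c4)cc3c2=O)c1` differs from compound 2 by methoxy in place of chloro on an aromatic carbon, on an aromatic carbon of a six-membered aromatic ring with one nitrogen, next to the ring nitrogen, meta to a large group. Among the compounds with values here, the only step that touches this position is an at least 9.5-fold higher number from compound 1 to compound 2 (0.97 log units; beyond the scatter), and it points from a smaller group toward a weaker result. Nothing measured tells how a methoxy group at this place behaves, so the expected step from compound 2 to compound 3 is an at least 1.2-fold lower number from compound 2 to compound 3 (0.09 log units; that floor lies within the scatter), most likely small. Compound 3 is therefore expected to give about 8000 nM in this assay, somewhere between 1500 nM and 30000 nM.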

Compound 3, half-maximal inhibitory concentration: > 10000 nM
Compound 3: no number, only a limit; the forecaster's own chance of this, stated with the estimate: 45%; middle value at least 1.2-fold (0.09 log units) away from the limit.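

Replacing fluoro with methoxy at this place gives an at least 9.5-fold higher number from compound 1 to compound 3 (0.97 log units; beyond the scatter), so in this assay chloro is no longer the only replacement for fluoro that ends at a limit. The step between compound 2 and compound 3 cannot be read, so chloro and methoxy cannot be ranked against each other. Of the three groups at this place, only the fluoro of compound 1 still gives a number, and the other two stop at the same limit: the limit of > 10000 nM in this assay, at which 2 of the 3 values shown sit.

Going by these compounds, it remains open whether an amine or a methyl group at this place would give a number, and whether any group here could give a lower number than compound 1 at 1050 nM. On these data alone, how far beyond their shared limit compound 2 and compound 3 really lie also remains unknown.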